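This account rests on a few compounds, and the source may have more. Where it says the series, first, only, none or still open, it means among the compounds named here.

Three compounds share one core. Compound 1 `COc1ccc(-c2cc(C(C)=O)c3[nH]c(-c4ccccc4)cc3c2)cc1` gives 73.1% in a functional assay on HeLa cells (Homo sapiens) for cytotoxicity, read by MTT assay, with a stated time of 2 days, tested at 1 uM; a lower number here means a stronger effect, a higher number a weaker effect of the compound at the concentration tested. Going by the values given here, compound 2 `COc1ccc(-c2cc(C(C)=O)c3[nH]c(-c4ccc(F)cc4)cc3c2)cc1` gives 56.1% in this assay, and a number 17 percentage points lower from compound 1 to compound 2 (beyond the scatter) is the only single change measured so far. Compound 3 `COc1ccc(-c2cc3cc(-c4ccc(F)cc4)cc(C(C)=O)c3[nH]2)cc1` gives 62.9% in this assay; it stands second highest of the three, within the scatter of compound 2 and beyond the scatter against compound 1. Compound 4 `COc1ccc(-c2cc(C(C)=O)c3[nH]c(-c4ccc(OC)cc4)cc3c2)cc1` has not yet been measured; it differs from compound 3 by methoxy in place of fluoro on an aromatic carbon. Among the compounds with values here, no measured step exchanges fluoro for methoxy, so the step between compound 1 and compound 2 bears on it only loosely. Compound 4 is therefore expected to move by a number 2.1 percentage points higher from compound 3 to compound 4 (within the scatter) at most, within the scatter. Compound 4 is estimated at 65% in this assay, in the range 50% to 80%.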

Compound 4, a percentage reported as activity, at one concentration (the size of the read-out at that concentration, not a potency): 60.2%
The estimate for compound 4 lay 4.8 percentage points above the measured number, and the stated range covers the measured number.
By their numbers in this assay, from the lowest: compounds 2, 4 and 3 (each within the scatter of the next); then compound 1.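

In this assay, the exchange of 4-fluorophenyl to 4-methoxyphenyl, para to a large group, shows a number 4.1 percentage points higher from compound 2 to compound 4 (within the scatter) and a number 2.7 percentage points lower from compound 3 to compound 4 (within the scatter), so at this place methoxy cannot be told apart from fluoro. Methoxy in place of hydrogen gives a number 12.9 percentage points lower from compound 1 to compound 4 (beyond the scatter), a step beyond the scatter, as fluoro gave for compound 2. No available evidence accounts for these results.

Going by these compounds, whether an amine, a carboxylic acid or a longer alkoxy chain at this place would give a number near these remains open. The read-out comes from a single concentration and shows only a stronger or weaker effect at that concentration.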